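The source may hold more compounds than are shown below. What is called first, only, known or untested is meant among the compounds shown, and "the series" means these compounds.

In a functional assay on BXPC-3 cells (Homo sapiens) for antiproliferative activity, read by MTT assay, with a stated time of 24 h (a higher number here means a weaker inhibitor, a lower number a stronger inhibitor), compound 2, with the structure `CCn1c(C(=O)NC(C)(C)CO)ccc1C(CC)(CC)c1ccc(OCS(=O)(=O)c2ccccc2)c(C)c1`, gives 18300 nM, the only outright number shown for the pair measured so far. Compound 1, `CCn1c(C(=O)NCCC(=O)OC)ccc1C(CC)(CC)c1ccc(OCS(=O)(=O)c2ccccc2)c(C)c1`, reaches only a limit of this assay and is reported as > 50000 nM. Among the measured compounds shown here, the step of an at least 2.7-fold lower number from compound 1 to compound 2 (0.43 log units; beyond the scatter) is the single measured change at the amide-type nitrogen, and its size is set by that limit (the limit of > 50000 nM in this assay, at which 1 of the 2 values shown sits). Compound 3, `CCn1c(C(=O)NCCCO)ccc1C(CC)(CC)c1ccc(OCS(=O)(=O)c2ccccc2)c(C)c1`, differs from compound 2 by 3-hydroxypropyl in place of 1-(hydroxymethyl)-1-methylethyl on an amide-type nitrogen. For the measured compounds named here, since the 3-hydroxypropyl group and the 1-(hydroxymethyl)-1-methylethyl group match in the donors and acceptors counted above, and the one measured step at this position involved the unrelated 2-(methoxycarbonyl)ethyl group, the expectation for compound 3 is a step of a 1.1-fold higher number from compound 2 to compound 3 (0.04 log units; within the scatter) in this assay, within the scatter. The estimate for compound 3 in this assay is therefore 20000 nM, with a range from 8000 nM to 50000 nM.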

Compound 3, half-maximal inhibitory concentration: 26600 nM
Beside the measured number, compound 3's estimate is 1.3-fold (0.12 log units) below it, and the stated range covers the measured number.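

Moving from 1-(hydroxymethyl)-1-methylethyl to 3-hydroxypropyl on the amide-type nitrogen gives a 1.5-fold higher number from compound 2 to compound 3 (0.16 log units; within the scatter), so this assay does not separate these two groups. Hydroxymethyl in place of methoxycarbonyl on the saturated chain carbon, two bonds along the chain from the amide-type nitrogen, gives an at least 1.8-fold lower number from compound 1 to compound 3 (0.27 log units; that floor lies within the scatter), so this single change is not shown to matter beyond the scatter, although the step from compound 1 to compound 2 was. Compound 1 stands at a limit of the assay, not at a number: the limit of > 50000 nM in this assay, at which 1 of the 3 values shown sits.

On these data alone, it remains open how large the steps from compound 1 really are. As far as these compounds go, it also remains open whether an amine, a carboxylic acid or a longer chain ending in hydroxyl on this nitrogen would shift the number beyond the scatter.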